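The source may report more compounds than this note shows. Statements on the series, on what has been measured and on what is new or still open speak of the compounds shown alone.

Working notes on the series. The shared core is carried by compound 1 `CCCCOc1cc(C(N)=O)nn1-c1ccccc1`, compound 2 `CCCCOc1cc(C(=O)N(C)C)nn1-c1ccccc1` and compound 3 `CCCCNC(=O)c1cc(OCCCC)n(-c2ccccc2)n1`; compound 4 `CCCCOc1cc(C(=O)N(CC)CC)nn1-c1ccccc1` is not yet measured. In a functional assay on the whole organism (strain Wistar) for inhibition, with Rattus norvegicus as the target, read by paw edema, with stated times of 30 min and 3 h, at a dose of 100 mg/kg by the oral route (a lower number here means less inhibition, a higher number more inhibition at the dose given (going by the name of the read-out)), compound 1 gives 26.5%, compound 2 gives 18.7% and compound 3 gives 43.3%. For the measured compounds named here, compound 3 stands highest of the three numbers measured so far: a number 16.8 percentage points higher from compound 1 to compound 3 (beyond the scatter) and a number 24.6 percentage points higher from compound 2 to compound 3 (beyond the scatter), both beyond the scatter, whereas a number 7.8 percentage points lower from compound 1 to compound 2 (within the scatter) stays within it.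

The step to compound 4 is diethylamino in place of butylamino on a carbonyl carbon. Going by the values given here, two measured steps bear on it. The most direct is the exchange on the carbonyl carbon between compound 2 and compound 3, a number 24.6 percentage points higher from compound 2 to compound 3 (beyond the scatter), which the present change partly reverses, since diethylamino is closer in kind to the dimethylamino of compound 2 than to the butylamino of compound 3. The other is a number 7.8 percentage points lower from compound 1 to compound 2 (within the scatter), which shows that dimethylamino in place of amino did not move the number beyond the scatter. Taken together, the expected direction in this assay for compound 4 is downward, with a step of roughly the size seen between compound 2 and compound 3 but not necessarily all of it; the expected step is a number 20.3 percentage points lower from compound 3 to compound 4 (beyond the scatter). Compound 4 is therefore estimated at 23% in this assay, with a range from 9% to 38%.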

Compound 4, a percentage reported as inhibition, in the whole organism at one dose (the size of the read-out at that dose, not a potency): 44.1%
The estimate for compound 4 lay 21.1 percentage points below the measured number, outside the stated range (above it).
By their numbers in this assay, from the lowest: compounds 2 and 1 (each within the scatter of the next); then compounds 3 and 4 (each within the scatter of the next).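

In this assay, the amide hydrogen proves not to be needed at this position: a number 0.8 percentage points higher from compound 3 to compound 4 (within the scatter), so diethylamino, with no hydrogen-bond donor, stands level with butylamino, which has one. Nor does replacing both hydrogens on the amide nitrogen by itself account for the low number of compound 2, since a number 25.4 percentage points higher from compound 2 to compound 4 (beyond the scatter) and a number 17.6 percentage points higher from compound 1 to compound 4 (beyond the scatter); among these four compounds, the two groups with 4 carbon atoms stand apart from amino and dimethylamino, whatever their arrangement. Nothing available here explains why these groups separate in this way.

The compounds shown leave open whether the number continues to follow the size of the group on the carbonyl carbon or has already reached a plateau, which dipropylamino or a longer chain such as hexylamino could address. They also leave open whether the two chains must remain separate or can be closed into a ring, as in pyrrolidine or piperidine amides, and whether an intermediate group such as ethylamino falls with the lower pair or the upper pair.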